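This account rests on a few compounds, and the source may have more. Where it says the series, first, only, none or still open, it means among the compounds named here.

Compound 1 `Cc1ccc(C(=O)NC(=O)c2ccccc2O)cc1` gives 46 ug/mL in an ADME assay on L6 cells (Rattus norvegicus) for cytotoxicity, read by resazurin assay, with a stated time of 72 h (a lower number here means a stronger inhibitor, a higher number a weaker inhibitor), the lower of the two numbers in hand, although its gap to compound 2 is within the scatter. Compound 2 `N#Cc1ccc(C(=O)NC(=O)c2ccccc2O)cc1` gives 55 ug/mL in this assay, and the step of a 1.2-fold higher number from compound 1 to compound 2 (0.08 log units; within the scatter) shows that exchanging the group on this aromatic carbon left the number essentially unchanged. Compound 3 `CCCCOc1ccc(C(=O)NC(=O)c2ccccc2O)cc1` is not yet measured; it differs from compound 1 by butoxy in place of methyl on an aromatic carbon. Within the data shown here, only the step from compound 1 to compound 2 bears on this, and it stayed within the scatter, so no step beyond the scatter is expected in this assay, with at most a slight shift toward a lower number. Compound 3 is therefore estimated at 35 ug/mL, between 15 ug/mL and 80 ug/mL, which would mean a step of a 1.3-fold lower number from compound 1 to compound 3 (0.12 log units; within the scatter).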

Compound 3, half-maximal inhibitory concentration: 13 ug/mL
Compound 3: the middle estimate sits 2.7-fold (0.43 log units) above what was measured; the whole stated range lies above it.
By their numbers in this assay, from the lowest: compound 3; then compounds 1 and 2 (each within the scatter of the next).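

The carbon para to a large group is not indifferent to substitution in this assay: butoxy lowers the number beyond the scatter (a 3.5-fold lower number from compound 1 to compound 3 (0.55 log units; beyond the scatter)) and does so against cyano as well (a 4.2-fold lower number from compound 2 to compound 3 (0.63 log units; beyond the scatter)). The methyl-to-cyano exchange had shown no such movement (a 1.2-fold higher number from compound 1 to compound 2 (0.08 log units; within the scatter)). No measurement in hand accounts for this shift.

As far as these compounds go, whether the chain, its ether oxygen or both carry the step remains open. A butyl chain, a methoxy group, a longer alkoxy chain or an amine on this carbon would bear on that.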